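The compounds below may be only part of what the source reports. "The series", "measured", "known", "first", "only" and "open" are said of these compounds alone.

Of the compounds shown here, two that share one core have been measured. Compound 1 `CC1(C)CCN(Cc2ccc(N3CC(=O)NC4(CCN(c5ccnc6[nH]ccc56)CC4)C3)cc2)CC1` gives 4500 nM in an assay on Sf9 cells for inhibition of N6-adenosine-methyltransferase catalytic subunit (Homo sapiens), read by TR-FRET; on this read-out higher numbers stand for weaker inhibition and lower numbers for stronger inhibition. Compound 2 `CC(C)Nc1cc(N2CCC3(CC2)CN(c2ccc(CN4CCC(C)(C)CC4)cc2)CC(=O)N3)ncn1` gives 330 nM in this assay. Among the compounds with values here, the only step between measured compounds is a 14-fold lower number from compound 1 to compound 2 (1.13 log units; beyond the scatter), a swap made on an amine nitrogen in a ring. Among these two numbers compound 2 stands lowest, with compound 1 as its only and nearest neighbour.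

Compound 3 `CN(C)c1cc(N2CCC3(CC2)CN(c2ccc(CN4CCC(C)(C)CC4)cc2)CC(=O)N3)ncn1` differs from compound 2 by dimethylamino in place of isopropylamino on an aromatic carbon. Within the data shown here, no measured step touches this place or this kind of exchange; the single known step concerns another part of the molecule and cannot guide the size here. Trimming a small amine like this is expected to move the number little, if at all beyond the scatter, with a modest rise the more likely direction. Compound 3 is therefore expected to give about 550 nM in this assay, within 150 nM to 2000 nM. The expected step is a 1.7-fold higher number from compound 2 to compound 3 (0.22 log units; within the scatter).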

Compound 3, half-maximal inhibitory concentration: 970 nM
Beside the measured number, compound 3's estimate is 1.8-fold (0.25 log units) below it; the measured number falls inside the stated range.
By their numbers in this assay, from the lowest: compound 2; then compound 3; then compound 1.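

In this assay, the small amine on this aromatic carbon proves to matter: dimethylamino in place of isopropylamino gives a 2.9-fold higher number from compound 2 to compound 3 (0.47 log units; beyond the scatter), a modest step but one beyond the scatter. Compound 3 still holds an advantage over the two-ring group of compound 1, with a 4.6-fold lower number from compound 1 to compound 3 (0.67 log units; beyond the scatter), so the better number seen with the six-membered ring carrying 2 nitrogen does not depend entirely on isopropylamino. No measurement shown here explains the rise from isopropylamino to dimethylamino.

The exchange changes two things at once: the group goes from 1 hydrogen-bond donor to 0, and its count of heavy atoms changes as well, and this pair cannot tell which of them counts. Methylamino and cyclopropylamino at this position would be informative, and how a larger amine such as morpholine behaves also remains open.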